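A few compounds are considered here, and "the series" means these few. Any claim that something is new, unique, unknown or untested is made for them only; others in the source may bear on it.

Measured so far in a functional assay (B cells) with Mus musculus as the target; on this read-out lower numbers stand for an effect already at smaller amounts and higher numbers for an effect only at larger amounts of compound:
- compound 1, `CCn1c(=O)n(C2OC(CO)[C@@H](O)[C@H]2O)c2nc(N)nc(O)c21`: 15 uM
- compound 2, `Nc1nc(O)c2c(n1)n(C1OC(CO)[C@@H](O)[C@H]1O)c(=O)n2Cc1ccc(Cl)cc1`: 14 uM
- compound 3, `C=CCn1c(=S)n(C2OC(CO)[C@@H](O)C(O)[C@H]2O)c2nc(N)nc(O)c21`: 1 uM

Compound 2 stands second highest of the three numbers. Within the data shown here, its nearest neighbour is compound 1, and the one measured step, a 1.1-fold lower number from compound 1 to compound 2 (0.03 log units; within the scatter), lies within the scatter, so the two numbers cannot be told apart. Among the measured compounds shown here, compound 3 differs from compound 2 in several places at once, and no single step connects them; its value simply sits well below that of compound 2, beyond the scatter.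

Compound 4, `Nc1nc(O)c2c(n1)n(C1OC(CO)[C@@H](O)[C@H]1O)c(=O)n2Cc1ccc([N+](=O)[O-])cc1`, is the next member. Relative to compound 2 the change is nitro in place of chloro on an aromatic carbon.

For the measured compounds named here, only one measured step touches the same region of the structure: the step from the methyl of compound 1 to the 4-chlorophenyl of compound 2, which stayed within the scatter. Going by the values given here, no measured pair exchanges one group for another on the six-membered aromatic ring of carbon only, so there is nothing that speaks for a large move in either direction. The expectation is therefore a step within the scatter, no change at the digits printed from compound 2 to compound 4 (within the scatter). For compound 4 in this assay the expected value is 14 uM, with a range from 6 uM to 35 uM.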

Compound 4, concentration for half-maximal effect: 40 uM
Estimate against measurement, compound 4: 2.9-fold (0.46 log units) below; measured number outside the range, above it.
By their numbers in this assay, from the lowest: compound 3; then compounds 2 and 1 (each within the scatter of the next); then compound 4.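

In this assay, the group on the aromatic carbon para to a large group proves able to shift the number: a 2.9-fold higher number from compound 2 to compound 4 (0.46 log units; beyond the scatter), a modest step but the first beyond the scatter at this site. The methyl of compound 1 and the 4-chlorophenyl of compound 2 could not be told apart, yet 4-nitrophenyl in place of that same methyl gives a 2.7-fold higher number from compound 1 to compound 4 (0.43 log units; beyond the scatter), so exchanging methyl for a substituted phenyl is not neutral as such, and the outcome depends on what the phenyl carries. Nothing available accounts for the difference between nitro and chloro at this carbon.

Whether the higher number is particular to nitro remains open, as the compounds shown include neither a plain benzyl nor an amine, a carboxylic acid or a methoxy group on that ring carbon. Also open, going by these compounds, is how a longer chain in place of the benzyl would read, and whether the step from chloro to nitro would be of similar size on a core carrying other changes.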